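Chloro to Cyano on the Aromatic Ring of a Hydroxamic Acid

This account rests on a few compounds, and the source may have more. Where it says the series, first, only, none or still open, it means among the compounds named here.

Compound 1 `O=C(CCC1=CCN(Cc2cccc(Br)c2)C1=O)NO` — in a functional assay on MDA-MB-231 cells (Homo sapiens) for inhibition, read by sulforhodamine B assay (a lower number here means a stronger inhibitor of growth, a higher number a weaker inhibitor of growth), compound 1 gives 1990 nM
Compound 2 `O=C(CCC1=CCN(Cc2cccc(Cl)c2)C1=O)NO` — in this assay compound 2 gives 1990 nM

Of the compounds shown here, two have been measured so far, and both sit at the same reading. Within the data shown here, the only step among them, no change at the digits printed from compound 1 to compound 2 (within the scatter), is a halogen swap on the aromatic carbon, and it left the growth-inhibition value where it was. Compound 2 therefore stands level with compound 1; on the numbers shown there is nothing to separate the two.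

The next compound, compound 3 `N#Cc1cccc(CN2CC=C(CCC(=O)NO)C2=O)c1`, differs from compound 2 by cyano in place of chloro on an aromatic carbon. Among the measured compounds shown here, the one measured step that bears on this change is the chloro-for-bromo exchange at the same aromatic carbon, and it produced no movement beyond the scatter. For the measured compounds named here, no measured step in this set replaces a halogen with a cyano group, so the expectation rests on that single flat step alone. On that basis the step of a 1.0-fold higher number from compound 2 to compound 3 (0.00 log units; within the scatter) is expected to be small, without a clear direction. Compound 3 is accordingly estimated to give about 2000 nM in this assay, within a range from 700 nM to 6000 nM.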

Compound 3, concentration for 50% growth inhibition: 3600 nM
Compound 3: middle estimate off by 1.8-fold (0.26 log units), on the low side; measured number inside the range.
By their numbers in this assay, from the lowest: compounds 1, 2 and 3 (each within the scatter of the next).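

The cyano group is the first substituent shown at this aromatic carbon, meta to a large group, that is not a halogen, and it adds a hydrogen-bond acceptor and a triple bond that neither chloro nor bromo has. Even so, in this assay replacing chloro with cyano gives a 1.8-fold higher number from compound 2 to compound 3 (0.26 log units; within the scatter), and replacing bromo with cyano gives a 1.8-fold higher number from compound 1 to compound 3 (0.26 log units; within the scatter), so the flat reading seen with the halogen exchange now extends to a different kind of substituent, and none of the three compounds can be separated from the others. No measurement shown here offers an explanation for this reading.

The compounds shown leave open whether this position would stay as flat with a primary amine, a carboxylic acid or a methoxy group on the same carbon, since all three groups shown are small and none carries a charge. They also leave open how chloro, bromo or cyano would read on another carbon of the ring, and whether a longer chain leading to the hydroxamic acid would move the value in this assay.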